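The source may report more compounds than this note shows. Statements on the series, on what has been measured and on what is new or still open speak of the compounds shown alone.

Measured in a functional assay on the whole organism for inhibition, with Rattus norvegicus as the target, read by paw edema, with a stated time of 30 min; a lower number here means that less compound is needed, a higher number that more compound is needed for the effect:

compound 1 `Clc1ccc(OCC2=NCCO2)cc1` gives 51.2 mg/kg
compound 2 `Cc1ccccc1OCC1=NCCO1` gives 78.3 mg/kg
compound 3 `Cc1cc(OCC2=NCCO2)ccc1Cl` gives 60.2 mg/kg

Compound 3 differs from compound 1 by methyl in place of hydrogen on an aromatic carbon, and this step in this assay is a 1.2-fold higher number from compound 1 to compound 3 (0.07 log units; within the scatter). The difference between the core of compound 1 and the core of compound 2 is not broken down here. Compound 4 `Cc1ccc(OCC2=NCCO2)c(C)c1` differs from compound 2 by methyl in place of hydrogen on an aromatic carbon. This is the same kind of change as from compound 1 to compound 3, but the surroundings differ: in compound 3 the new methyl sits ortho to a chloro group and meta to a group of 7 heavy atoms, in compound 4 it sits meta to a methyl group and para to a group of 7 heavy atoms. Because the earlier step was a 1.2-fold higher number from compound 1 to compound 3 (0.07 log units; within the scatter), a step of a 1.1-fold higher number from compound 2 to compound 4 (0.04 log units; within the scatter) is expected here. Compound 4 is therefore estimated at 85 mg/kg in this assay, with a range from 50 mg/kg to 150 mg/kg.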

Compound 4, dose for half-maximal effect: 57.3 mg/kg
Compound 4: middle estimate off by 1.5-fold (0.17 log units), on the high side; the measured number falls inside the stated range.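

In this assay, methyl in place of hydrogen on an aromatic carbon gives a 1.4-fold lower number from compound 2 to compound 4 (0.14 log units; within the scatter), and the two steps seen so far do not differ by more than the usual spread of such data: the same change on two cores in this assay, a 1.2-fold higher number (0.07 log units; within the scatter) from compound 1 to compound 3 and a 1.4-fold lower number (0.14 log units; within the scatter) from compound 2 to compound 4, 1.6-fold (0.21 log units) apart, within the scatter of two such steps

On these two cores, then, the change leaves the number within the scatter each time, so a small step carried from one core to the other fits the data. This does not show that the change carries over in general, since it rests on two pairs with the methyl in different surroundings, and steps this small show no real direction.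

The compounds shown leave open whether another group at this place, such as an amine or a carboxylic acid, would give a step beyond the scatter.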